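The source may hold more compounds than are shown below. What is called first, only, known or untested is meant among the compounds shown, and "the series" means these compounds.

Compound 1 `CC1(c2nc(-c3ccc(CNC(=O)[C@H]4NCC[C@@H]4O)cc3)no2)CCCCC1` is one of three compounds whose numbers are known in an assay on isolated protein for inhibition of sphingosine kinase 1 (Homo sapiens); a lower number here means a stronger inhibitor, a higher number a weaker inhibitor. Among the three compounds 1 stands second highest: in this assay compound 1 gives 210 nM. Its nearest neighbour is compound 3 `CC[C@H](NC(=O)[C@H]1NCC[C@@H]1O)c1ccc(-c2noc(CCC3CCCC3)n2)cc1`, which in this assay gives 56 nM, a number beyond the usual scatter below that of compound 1. Furthest away is compound 2 `CCCCCCCc1nnc(-c2ccc(CNC(=O)[C@H]3NCC[C@@H]3O)cc2)o1`, which in this assay gives 2200 nM, a number beyond the scatter above that of compound 1.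

Compound 4 `CCCCCCCCc1nc(-c2ccc(CNC(=O)[C@H]3NCC[C@@H]3O)cc2)no1` has not yet been measured in this assay. It differs from compound 1 in one place: octyl in place of 1-methylcyclohexyl on an aromatic carbon. The branched ring is thus traded for a straight chain of about the same size, on the same carbon of the shared core.

Among the measured compounds shown here, no pair of measured compounds differs in exactly this way, so the size of this step is not known. Compound 2, which carries a straight heptyl chain on a different five-membered ring, gives 2200 nM, a weaker number than compound 1, but its ring differs from that of compound 4, so it can only hint. The step from compound 1 to compound 4 is expected to be a 2.4-fold higher number from compound 1 to compound 4 (0.38 log units; beyond the scatter), a moderate move toward weaker inhibition. Compound 4 is therefore estimated at 500 nM, with a range from 150 nM to 1800 nM.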

Compound 4, half-maximal inhibitory concentration: 86 nM
Compound 4: middle estimate off by 5.8-fold (0.76 log units), on the high side; measured number below the stated range.
By their numbers in this assay, from the lowest: compounds 3 and 4 (each within the scatter of the next); then compound 1; then compound 2.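

In this assay the change from 1-methylcyclohexyl to octyl gives a 2.4-fold lower number from compound 1 to compound 4 (0.39 log units; beyond the scatter) and so shows that this carbon of the five-membered aromatic ring does not need a ring-bearing, branched group for inhibition to hold up. A flexible-looking straight chain might have been expected to lose ground here, yet on this core the open chain does modestly better than the ring. This single swap removes the ring, removes the branch and adds one carbon all at once, so the step cannot be divided among those three changes, and nothing measured on these compounds explains the gain.

The compounds shown leave open how the number moves with chain length at this position, for example with a hexyl or a decyl chain in place of octyl on the same core. They also leave open whether this carbon tolerates a chain ending in an amine or a carboxylic acid, or a phenyl ring in place of the saturated ring of compound 1.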